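The source may hold more compounds than are shown below. What is called first, only, known or untested is meant among the compounds shown, and "the series" means these compounds.

Measured in a functional assay on QGY-7703 cells (Homo sapiens) for cytotoxicity, read by MTT assay, with a stated time of 24 h; a lower number here means a stronger inhibitor, a higher number a weaker inhibitor:

- compound 1 `COc1cc(/C=C2\CN(S(=O)(=O)c3ccc(F)cc3)C/C(=C\c3ccccc3F)C2=O)cc(OC)c1` gives 14000 nM
- compound 2 `CC(=O)Nc1ccc(S(=O)(=O)N2C/C(=C\c3cccc([N+](=O)[O-])c3)C(=O)/C(=C/c3ccccc3F)C2)cc1` gives 7850 nM
- compound 3 `COc1cc(/C=C2\CN(S(=O)(=O)c3ccc(NC(C)=O)cc3)C/C(=C\c3ccccc3F)C2=O)cc(OC)c1OC` gives 2680 nM

Compound 3 has the lowest number of the three, which makes it the strongest inhibitor here. Compound 4 `COc1cc(/C=C2\CN(S(=O)(=O)c3ccc(NC(C)=O)cc3)C/C(=C\c3ccccc3F)C2=O)cc(OC)c1` differs from compound 3 in one place (hydrogen in place of methoxy on an aromatic carbon), turning 3,4,5-trimethoxyphenyl into 3,5-dimethoxyphenyl. Among the compounds with values here, the one measured step that touches this group is modest: a 2.9-fold lower number from compound 2 to compound 3 (0.47 log units; beyond the scatter). Compound 1 also carries 3,5-dimethoxyphenyl and gives 14000 nM, but it differs from compound 4 elsewhere too, so it is only a loose guide. Within the data shown here, no measured pair isolates this methoxy, so a modest rise in this assay is expected. The expected step is a 1.9-fold higher number from compound 3 to compound 4 (0.27 log units; within the scatter). For compound 4 the estimated value is 5000 nM, within an expected range of 2200 nM to 11000 nM.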

Compound 4, half-maximal inhibitory concentration: 3690 nM
Compound 4: the middle estimate sits 1.4-fold (0.13 log units) above what was measured; measured number inside the range.
By their numbers in this assay, from the lowest: compounds 3 and 4 (each within the scatter of the next); then compounds 2 and 1 (each within the scatter of the next).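

In this assay, within the data shown here, the methoxy is isolated by a single pair for the first time: hydrogen in its place gives a 1.4-fold higher number from compound 3 to compound 4 (0.14 log units; within the scatter) and so makes no clear difference. The 3-nitrophenyl comparison still holds for 3,5-dimethoxyphenyl, with a 2.1-fold lower number from compound 2 to compound 4 (0.33 log units; beyond the scatter) as the step, so the third methoxy is not needed for that gain. Acetamido in place of fluoro gives a 3.8-fold lower number from compound 1 to compound 4 (0.58 log units; beyond the scatter) and no measured evidence explains any of these steps.

From the compounds shown here alone, whether a hydroxyl or an amine at this place would shift the number stays open. So does whether removing the methoxy would have the same small effect with fluoro in place of acetamido.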